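The source may report more compounds than this note shows. Statements on the series, on what has been measured and on what is new or still open speak of the compounds shown alone.

Measured in a functional assay on NCI-H727 cells (Homo sapiens) for cytotoxicity, with a stated time of 48 h; a higher number here means a weaker inhibitor, a lower number a stronger inhibitor:
- compound 1 `COc1cc(OC)c(C(=O)/C=C/c2ccccc2SC)c(OC)c1`: 8700 nM
- compound 2 `COc1cc(OC)c(C(=O)/C=C/c2ccccc2)c(OC)c1`: 11400 nM
- compound 3 `COc1cc(OC)c(C(=O)/C=C/c2ccc(Br)cc2)c(OC)c1`: 11300 nM

Compound 1 stands level with the other two, as a 1.3-fold higher number from compound 1 to compound 2 (0.12 log units; within the scatter) and a 1.3-fold higher number from compound 1 to compound 3 (0.11 log units; within the scatter) leave no order among them. Compound 4 `COc1cc(O)c(C(=O)/C=C/c2ccccc2SC)c(OC)c1` alters compound 1 at a new place: hydrogen in place of methyl on an oxygen on an aromatic ring, which turns methoxy to hydroxy. Going by the values given here, no measured step touches this place, so the evidence is indirect. Changes elsewhere have moved this assay little, as a 1.0-fold lower number from compound 2 to compound 3 (0.00 log units; within the scatter) shows, and the same holds for the two steps from compound 1. A step beyond the scatter is therefore not expected, in either direction, though the range must stay wide. The expected step is a 1.1-fold lower number from compound 1 to compound 4 (0.04 log units; within the scatter). For compound 4 the estimated value is 8000 nM, with an expected range from 3000 nM to 20000 nM.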

Compound 4, half-maximal inhibitory concentration: 9000 nM
The estimate for compound 4 lay 1.1-fold (0.05 log units) below the measured number, within the range that was stated.
By their numbers in this assay, from the lowest: compounds 1, 4, 3 and 2 (each within the scatter of the next).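

Turning methoxy to hydroxy on this oxygen is the first change at this place, and it gives a 1.0-fold higher number from compound 1 to compound 4 (0.01 log units; within the scatter) in this assay. Losing this one methyl therefore leaves the number within the scatter, so this assay does not tell compound 1 and compound 4 apart. No measurement available here explains this result. As far as these compounds go, whether a longer chain or a chain ending in an amine on this oxygen would behave the same remains open. So does whether hydroxy would have the same small effect on compound 2 or compound 3.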